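The source may report more compounds than this note shows. Statements on the series, on what has been measured and on what is new or still open speak of the compounds shown alone.

Working notes on the series. The shared core is seen bare in compound 2 `O=C1c2c[n+]([O-])c3ccccc3c2C(=O)c2[nH]c3ccccc3c21`. In a functional assay on SH-SY5Y cells (Homo sapiens) for cytotoxicity, read by MTT assay, with a stated time of 72 h (on this read-out lower numbers stand for stronger inhibition and higher numbers for weaker inhibition), compound 2 gives 1380 nM, the higher of the two numbers recorded; its nearest neighbour is compound 3 `CC1(C)OCC(Cn2cc(Cn3c4c(c5ccccc53)C(=O)c3c[n+]([O-])c5ccccc5c3C4=O)nn2)O1`, which in this assay gives 230 nM, a gap beyond the scatter. Compound 1 `CC1(C)O[C@@H](CO)[C@H](Cn2cc(Cn3c4c(c5ccccc53)C(=O)c3c[n+]([O-])c5ccccc5c3C4=O)nn2)O1` reaches only a limit in this assay, > 1000 nM, and that is all its value tells (the limit of > 1000 nM in this assay, at which 1 of the 3 values shown sits). Among the compounds with values here, the one measured step, an at least 4.3-fold lower number from compound 1 to compound 3 (0.63 log units; beyond the scatter), concerns a group on a saturated chain carbon, not the aromatic nitrogen itself. Compound 4 `CN(C)CCCCn1c2c(c3ccccc31)C(=O)c1c[n+]([O-])c3ccccc3c1C2=O` differs from compound 2 by 4-(dimethylamino)butyl in place of hydrogen on an aromatic nitrogen. Within the data shown here, no measured step covers a chain entering at this nitrogen; the only bearing is indirect, in that compound 3, which also carries a group on the aromatic nitrogen, stands lower than compound 2. A modest downward step is therefore expected, a 3.9-fold lower number from compound 2 to compound 4 (0.60 log units; beyond the scatter), with wide uncertainty. Compound 4 is estimated at 350 nM, within 80 nM to 1500 nM.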

Compound 4, half-maximal inhibitory concentration: 250 nM
Compound 4: middle estimate off by 1.4-fold (0.15 log units), on the high side; measured number inside the range.
By their numbers in this assay, from the lowest: compounds 3 and 4 (each within the scatter of the next); then compound 2.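

Within the data shown here, this is the first direct reading of a change at the aromatic nitrogen itself: in this assay, the bare core gives way to an open chain with no ring, with a 5.5-fold lower number from compound 2 to compound 4 (0.74 log units; beyond the scatter) as the result. Compound 3 and compound 4 stand within the scatter of each other, so two quite different groups on this nitrogen read alike here, and a ring in the entering group is not needed to reach this level. Nothing measured in the series gives a cause for the step.

Going by these compounds, it remains open whether the step follows the butyl chain or its dimethylamino end. A plain butyl group, a longer chain ending in the same amine, or a morpholine at the chain end would help to separate the two.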